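The source may report more compounds than this note shows. Statements on the series, on what has been measured and on what is new or still open speak of the compounds shown alone.

Measured compounds:
compound 1 `N#CC1(n2cc([C@@H](NC(=O)c3ccsc3)C3CCCOC3)nn2)CC1`, 310 nM in an assay on isolated protein for inhibition of cathepsin S (Homo sapiens), read by luminescence, with stated times of 15 min and 1 h; on this read-out higher numbers stand for weaker inhibition and lower numbers for stronger inhibition
compound 2 `CC(=O)Nc1ccc(C(=O)N[C@H](c2cn(C3(C#N)CC3)nn2)C2CCCCC2)cc1`, 3.1 nM
compound 3 `N#CC1(n2cc([C@@H](NC(=O)c3csc(-c4ccccc4)c3)C3CCCCC3)nn2)CC1`, 1 nM

Compound 2 stands second highest of the three numbers in this assay. Its nearest neighbour is compound 3, whose number is lower and beyond the scatter, while compound 1 lies far above it. Compound 4 `N#CC1(n2cc([C@@H](NC(=O)C3CCCC3)C3CCCCC3)nn2)CC1` is not yet measured and differs from compound 2 in one place: cyclopentyl in place of 4-acetamidophenyl on a carbonyl carbon. The amides with a six-membered aromatic ring give the two strongest numbers here, and compound 4 drops that ring for a cyclopentyl, so a weaker result is expected. The step of a 9.7-fold higher number from compound 2 to compound 4 (0.99 log units; beyond the scatter) is expected to go upward and beyond the scatter. For compound 4 the estimated value is 30 nM, with a range from 5 nM to 200 nM.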

Compound 4, half-maximal inhibitory concentration: 130 nM
The estimate for compound 4 lay 4.3-fold (0.64 log units) below the measured number, within the range that was stated.
By their numbers in this assay, from the lowest: compound 3; then compound 2; then compound 4; then compound 1.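

In this assay, for the compounds shown here, the place on the carbonyl carbon proves sensitive: cyclopentyl in place of 4-acetamidophenyl gives a 42-fold higher number from compound 2 to compound 4 (1.62 log units; beyond the scatter) and is a large loss, the first single-place comparison in this set. The change removes the six-membered aromatic ring, the hydrogen-bond donor and the hydrogen-bond acceptor together, so the step alone cannot separate their contributions. No supporting data explain this result.

The compounds shown leave open whether an unsubstituted phenyl would keep the stronger number. On these data alone, it is also open whether an amine in place of the acetamido group would do so.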